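The source may report more compounds than this note shows. Statements on the series, on what has been measured and on what is new or still open speak of the compounds shown alone.

Compound 1 `Cc1ccc(SCc2ccc(C(=O)Nc3ccccc3N)cc2)cc1` gives the highest of the three numbers in a functional assay on A549 cells (Homo sapiens) for inhibition, read by CCK-8 assay, with a stated time of 72 h, tested at 8 uM (on this read-out higher numbers stand for more inhibition of growth at the one concentration tested and lower numbers for less inhibition of growth), with 78.3%. Compound 3 `CC(C)(C)c1ccc(SCc2ccc(C(=O)Nc3ccccc3N)cc2)cc1` gives 67%, and compound 2 `Nc1ccccc1NC(=O)/C=C/c1ccc(CSc2cccc(F)c2)cc1` gives 56.6%. Going by the values given here, the step of a number 11.3 percentage points lower from compound 1 to compound 3 (beyond the scatter) is the one measured single-place change among the three; compound 2 differs from compound 1 in more than one place and does not bear directly on a single change. Compound 4 `Nc1ccccc1NC(=O)c1ccc(CSCCc2ccccc2)cc1` differs from compound 1 as follows: phenethyl in place of 4-methylphenyl on a sulfur. Among the compounds with values here, the one measured step, a modest lowering from a larger group, is the only footing, and the present change is of a different kind, so a downward step of similar or smaller size is expected in this assay. Compound 4 is expected to give 66%, between 50% and 80%, an expected step of a number 12.3 percentage points lower from compound 1 to compound 4 (beyond the scatter).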

Compound 4, percent growth inhibition at one concentration: 84.1%
Compound 4: the middle estimate sits 18.1 percentage points below what was measured; the measured number lies above the stated range.
By their numbers in this assay, from the lowest: compound 2; then compound 3; then compounds 1 and 4 (each within the scatter of the next).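

With phenethyl in place of 4-methylphenyl on a sulfur, this assay shows a number 5.8 percentage points higher from compound 1 to compound 4 (within the scatter). The aromatic ring therefore need not sit directly on the sulfur for the number to hold, whereas the change at the far end of the ring, a number 11.3 percentage points lower from compound 1 to compound 3 (beyond the scatter), did not leave it within the scatter. Nothing measured here accounts for this tolerance.

Still open, from the compounds shown here alone, is whether a benzyl group or a longer chain ending in phenyl on the sulfur would keep the number. Going by these compounds, the effect of an amine or a carboxylic acid on the phenethyl ring also remains open.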